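The compounds below may be only part of what the source reports. "The series", "measured", "known", "first", "only" and "open" are said of these compounds alone.

Among the compounds with values here, in a functional assay on VCaP cells (Homo sapiens) for antiproliferative activity, read by CCK-8 assay, with a stated time of 6 days (on this read-out lower numbers stand for stronger inhibition and higher numbers for weaker inhibition), compound 1 (`CCN(c1ccc(C#N)c(Cl)c1)c1cc(-c2ccnn2C)ccc1C`) gives 1670 nM and is the only compound with a number so far. As far as these compounds go, compound 2 (`CCN(c1ccc(C#N)c(Cl)c1)c1cc(-c2cn[nH]c2)ccc1C`) has the entry "not determined" (no result reported) in this assay and therefore offers no value to work from, so its standing relative to compound 1 remains open. The next compound is compound 3 (`CCN(c1ccc(C#N)c(Cl)c1)c1cc(-c2cccnc2)ccc1C`). The structural change is pyridin-3-yl in place of 1H-pyrazol-4-yl on an aromatic carbon and puts pyridin-3-yl in place of 1H-pyrazol-4-yl on an aromatic carbon of a six-membered aromatic ring of carbon only, meta to a large group and para to a methyl group. Within the data shown here, no measured step exists for this swap, so neither its size nor its direction can be read from the data. The working expectation in this assay is therefore no shift beyond the usual scatter, with compound 1 at 1670 nM as the sole reference level and neither direction favoured. The uncertainty is wide on a single reference point. For compound 3 the expected value is 1500 nM with an estimated range from 400 nM to 5000 nM in this assay.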

Compound 3, half-maximal inhibitory concentration: 1270 nM
Compound 3: the middle estimate sits 1.2-fold (0.07 log units) above what was measured; low and high end bracket the measured number.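

In this assay, within the data shown here, replacing 1-methyl-1H-pyrazol-5-yl with pyridin-3-yl on the aromatic carbon meta to a large group and para to a methyl group gives a 1.3-fold lower number from compound 1 to compound 3 (0.12 log units; within the scatter), the first step that can be read at this position. For this pair, a five-membered aromatic ring with 2 hetero atoms and a six-membered aromatic ring with 1 hetero atom cannot be told apart on this read-out, so the change of ring size and hetero atom count shows no effect beyond the scatter, a finding that holds for compound 1 and compound 3 only. No measured evidence on any property of these groups is available to bear on this result.

As far as these compounds go, the step from compound 2 to compound 3 cannot be read, as compound 2 has no number, so how 1H-pyrazol-4-yl stands against either of the other two groups remains open. Also open, from the compounds shown here alone, is how this assay responds on the same aromatic carbon to a group of a different kind, such as a plain phenyl ring, an amine or a carboxylic acid.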